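Adding a hydroxy group to compound 2: an estimate

The source may report more compounds than this note shows. Statements on the series, on what has been measured and on what is new or still open speak of the compounds shown alone.

Measured compounds:
compound 1 `COc1ccc(C(=O)N(C)/N=C/c2ccc(OC)c(OC)c2)cc1` gives 81%
compound 2 `COc1ccc(/C=N/N(C)C(=O)c2ccccc2)cc1OC` gives 73%

Both compounds were tested in a functional assay on the whole organism (lung, strain A/J) for inhibition, with Mus musculus as the target, with stated times of 1 h and 18 h, at a dose of 100 umol/kg by the oral route; on this read-out higher numbers stand for more inhibition at the one dose given (going by the name of the read-out) and lower numbers for less inhibition. Compound 2 stands at the lower of the two numbers, yet its neighbour compound 1 sits within the scatter of it, so the two cannot be told apart. Within the data shown here, the only measured step, a number 8 percentage points lower from compound 1 to compound 2 (within the scatter), shows that removing a methoxy group left the read-out essentially unchanged.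

Compound 3 `COc1ccc(/C=N/N(C)C(=O)c2ccc(O)cc2)cc1OC` is not yet measured. It differs from compound 2 by hydroxy in place of hydrogen on an aromatic carbon; cut one bond further out, this reads as phenyl to 4-hydroxyphenyl. Among the measured compounds shown here, no measured step involves a hydroxy group, so the single known step gives no direct guide and only shows that a small change on this ring did not move the number. The step to compound 3 is therefore expected to be a number 1 percentage points lower from compound 2 to compound 3 (within the scatter), none beyond the scatter. Compound 3 is estimated at 72%, with a range from 50% to 90%.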

Compound 3, a percentage reported as inhibition, in the whole organism at one dose (the size of the read-out at that dose, not a potency): 65%
Estimate against measurement, compound 3: 7 percentage points above; low and high end bracket the measured number.
By their numbers in this assay, from the lowest: compounds 3, 2 and 1 (each within the scatter of the next, the first and the last beyond it).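

Placing a hydroxy group on this aromatic carbon gives in this assay a number 8 percentage points lower from compound 2 to compound 3 (within the scatter) so hydroxy and hydrogen cannot be told apart at this position. Comparing hydroxy with methoxy at the same place gives a number 16 percentage points lower from compound 1 to compound 3 (beyond the scatter) and this is the first step in the series to pass the scatter, showing that the methyl on this oxygen can change the read-out even though neither group is separated from hydrogen. Nothing available explains this difference.

The compounds shown leave open how an amine, a carboxylic acid or a longer chain such as ethoxy would behave at this position. They also leave open whether the difference between hydroxy and methoxy would hold at other doses, since each compound has a read-out at only one dose.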